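The source may report more compounds than this note shows. Statements on the series, on what has been measured and on what is new or still open speak of the compounds shown alone.

Working notes on the series.

Three compounds have been run in a functional assay on the whole organism (strain albino) for inhibition, with Rattus norvegicus as the target, read by paw edema, with stated times of 30 min and 4 h, at a dose of 100 mg/kg by the oral route; on this read-out lower numbers stand for less inhibition and higher numbers for more inhibition at the one dose given (going by the name of the read-out). Compound 1 `COc1ccc(/C=C/C(=O)c2ccc(NC(=O)CBr)cc2)cc1` gives 41%. Compound 2 `COc1ccc(/C=C/C(=O)c2ccc(NC(=O)CO[N+](=O)[O-])cc2)cc1` gives 51%. Compound 3 `CC(=O)c1ccc(OCC(=O)Nc2ccc(C(=O)/C=C/c3ccc(Cl)cc3)cc2)cc1` gives 58%. Compound 3 holds the highest of the three numbers; its gap to compound 2 is within the scatter, while its gap to compound 1 is beyond it, so compound 3 cannot be set apart from compound 2. Among the measured compounds shown here, the one single-point step measured so far, a number 10 percentage points higher from compound 1 to compound 2 (within the scatter), changes the chain next to the amide carbonyl and says nothing about the aromatic carbon that is altered next.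

Compound 4 `COc1ccc(/C=C/C(=O)c2ccc(NC(=O)COc3ccc(C(C)=O)cc3)cc2)cc1` differs from compound 3 by methoxy in place of chloro on an aromatic carbon, that is, 4-chlorophenyl becomes 4-methoxyphenyl. For the measured compounds named here, no measured pair isolates this change: compound 1 and compound 2 carry the methoxy but differ from compound 3 elsewhere as well. Going by the values given here, with no step to lean on, compound 4 is expected to sit close to compound 3, with a number 3 percentage points lower from compound 3 to compound 4 (within the scatter) not expected to go beyond the scatter. Compound 4 is estimated at 55%, with a range from 40% to 70% in this assay.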

Compound 4, a percentage reported as inhibition, in the whole organism at one dose (the size of the read-out at that dose, not a potency): 33%
The estimate for compound 4 lay 22 percentage points above the measured number, and the stated range ends above it.
By their numbers in this assay, from the lowest: compounds 4, 1, 2 and 3 (each within the scatter of the next, the first and the last beyond it).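

In this assay the aromatic carbon now has its first measured step, a number 25 percentage points lower from compound 3 to compound 4 (beyond the scatter), so methoxy in place of chloro at this place, para to a large group, gives a change beyond the scatter, though in this one pair only. With the 4-methoxyphenyl kept, the chain steps read a number 18 percentage points lower from compound 2 to compound 4 (beyond the scatter) for 4-acetylphenyl in place of nitro and a number 8 percentage points lower from compound 1 to compound 4 (within the scatter) for 4-acetylphenoxy in place of bromo, so the high number of compound 3 does not carry over to the 4-acetylphenoxy chain once methoxy replaces chloro. Nothing at hand accounts for the size of the step from chloro to methoxy.

From the compounds shown here alone, whether chloro in place of methoxy would raise the number on the bromo and nitrooxy chains stays open. Going by these compounds, how an amine or a carboxylic acid on this aromatic carbon would read also stays open.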